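A few compounds are considered here, and "the series" means these few. Any claim that something is new, unique, unknown or untested is made for them only; others in the source may bear on it.

Working notes on the series. Compound 1 `NC(=O)c1cc(-c2ccc(NS(=O)(=O)c3cccc(Cl)c3Cl)cc2)nc2[nH]ncc12` carries an unsubstituted amide; in an assay for inhibition of serine/threonine-protein kinase Sgk1 (Homo sapiens), with stated times of 30 min and 60 min, in the presence of a further agent that is not named here (on this read-out higher numbers stand for weaker inhibition and lower numbers for stronger inhibition), compound 1 gives 236 nM. Of the two plain numbers shown, compound 1 stands lowest. Compound 2 `CNC(=O)c1cc(-c2ccc(NS(=O)(=O)c3cccc(Cl)c3Cl)cc2)nc2[nH]ncc12`, with methyl on the amide nitrogen, gives 929 nM in this assay, the step being a 3.9-fold higher number from compound 1 to compound 2 (0.60 log units; beyond the scatter). Compound 3 `CN1CC(NC(=O)c2cc(-c3ccc(NS(=O)(=O)c4cccc(Cl)c4Cl)cc3)nc3[nH]ncc23)C1` carries 1-methylazetidin-3-yl on the same nitrogen. For compound 3 this assay reports only a limit, < 1 nM. The step from compound 1 to compound 3 reads an at least 230-fold lower number from compound 1 to compound 3 (2.37 log units; beyond the scatter), and from compound 2 it reads an at least 920-fold lower number from compound 2 to compound 3 (2.96 log units; beyond the scatter); both steps rest on (the limit of < 1 nM in this assay, at which 1 of the 3 values shown sits).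

Compound 4 `CCN1CCC(CNC(=O)c2cc(-c3ccc(NS(=O)(=O)c4cccc(Cl)c4Cl)cc3)nc3[nH]ncc23)C1` is not yet measured. Its difference from compound 1 is (1-ethylpyrrolidin-3-yl)methyl in place of hydrogen on an amide-type nitrogen. The step that bears most directly on it is the one where 1-methylazetidin-3-yl on the amide nitrogen gave an at least 230-fold lower number from compound 1 to compound 3 (2.37 log units; beyond the scatter); the methyl case, a 3.9-fold higher number from compound 1 to compound 2 (0.60 log units; beyond the scatter), points the other way but is modest. A large step toward lower numbers is therefore expected for compound 4 in this assay, of about a 79-fold lower number from compound 1 to compound 4 (1.90 log units; beyond the scatter). The estimate for compound 4 is 3 nM, within 0.5 nM to 30 nM.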

Compound 4, half-maximal inhibitory concentration: 109 nM
Estimate against measurement, compound 4: 36-fold (1.56 log units) below; the measured number lies above the stated range.
By their numbers in this assay, from the lowest: compound 4; then compound 1; then compound 2. At a limit, below all of these: compound 3.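

On the amide nitrogen in this assay, a substituent containing a saturated nitrogen ring does not by itself bring a large step: (1-ethylpyrrolidin-3-yl)methyl gives only a 2.2-fold lower number from compound 1 to compound 4 (0.34 log units; beyond the scatter), though the comparison with the methyl amide reads an 8.5-fold lower number from compound 2 to compound 4 (0.93 log units; beyond the scatter). The position therefore distinguishes sharply between two such substituents, with (1-ethylpyrrolidin-3-yl)methyl in place of 1-methylazetidin-3-yl giving an at least 100-fold higher number from compound 3 to compound 4 (2.03 log units; beyond the scatter). Compound 3 is reported only as a limit, so the size of that step is a bound and not an exact figure: the limit of < 1 nM in this assay, at which 1 of the 4 values shown sits.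

The change from 1-methylazetidin-3-yl to (1-ethylpyrrolidin-3-yl)methyl alters the ring, the link to the amide nitrogen and the alkyl group together, and the compounds shown do not separate these contributions. Open in particular is how (1-methylazetidin-3-yl)methyl, with the smaller ring kept and the link added, or 1-ethylazetidin-3-yl, with ethyl in place of methyl, would stand on the same nitrogen.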